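The source may report more compounds than this note shows. Statements on the series, on what has been measured and on what is new or still open speak of the compounds shown alone.

In a functional assay on A549 cells (Homo sapiens) for antiproliferative activity, read by MTT assay, with a stated time of 72 h; on this read-out higher numbers stand for weaker inhibition and lower numbers for stronger inhibition:

- compound 1 `Nc1ccccc1NC(=O)CCCCCCc1nc(-c2ccccc2)no1`: 23900 nM
- compound 2 `Nc1ccccc1NC(=O)CCCCCCc1nc(-c2ccc(Cl)cc2)no1`: 13800 nM

Compound 2 cannot be told apart from compound 1 on these numbers. Going by the values given here, the only measured step, a 1.7-fold lower number from compound 1 to compound 2 (0.24 log units; within the scatter), places chloro in place of hydrogen on an aromatic carbon and lies within the scatter.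

Compound 3 `Nc1ccccc1NC(=O)CCCCCCc1nc(-c2ccccc2Cl)no1` keeps the shared core of compound 2 and carries 2-chlorophenyl in place of 4-chlorophenyl on an aromatic carbon. Among the compounds with values here, no measured pair tests this exchange directly, so the step from compound 1 to compound 2 is the only guide, and it is a small one. No step beyond the scatter is therefore expected in this assay. The expected change is a 1.1-fold higher number from compound 2 to compound 3 (0.04 log units; within the scatter). For compound 3 the estimated value is 15000 nM, with an expected range from 7000 nM to 32000 nM.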

Compound 3, half-maximal inhibitory concentration: > 100000 nM
Compound 3 ended at the assay's limit (the forecaster's own chance of this, stated with the estimate: 4%); middle value at least 6.6-fold (0.82 log units) from the limit.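

this assay gives compound 3 the value > 100000 nM, which is a limit of the assay and not a number. Exchanging 4-chlorophenyl for 2-chlorophenyl gives an at least 7.2-fold higher number from compound 2 to compound 3 (0.86 log units; beyond the scatter), so with the same atoms joined differently, where the chloro sits on the phenyl ring decides the read-out at this position, which the earlier pair could not show. Set against the unsubstituted phenyl, chloro in place of hydrogen gives an at least 4.1-fold higher number from compound 1 to compound 3 (0.62 log units; beyond the scatter), whereas the same kind of exchange in a 1.7-fold lower number from compound 1 to compound 2 (0.24 log units; within the scatter) stayed within the scatter.

From the compounds shown here alone, how far compound 3 really lies from compound 1 and compound 2 stays open: the limit of > 100000 nM in this assay, at which 1 of the 3 values shown sits. Whether fluoro or methyl in place of the chloro of 2-chlorophenyl would also raise the number is left open as well.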